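This account rests on a few compounds, and the source may have more. Where it says the series, first, only, none or still open, it means among the compounds named here.

Compound 3 `Cc1ccc(C2C(C#N)=C(N)OC(c3c[nH]c4ccccc34)=C2C#N)cc1` stands lowest of the three measured compounds in a functional assay, tested at 100 ug/mL (a lower number here means a weaker effect, a higher number a stronger effect of the compound at the concentration tested), where compound 3 gives 5.5%. Compound 1 `COc1ccc(C2C(C#N)=C(N)OC(c3c[nH]c4ccccc34)=C2C#N)cc1OC` gives 19.1% and compound 2 `CN(C)c1ccc(C2C(C#N)=C(N)OC(c3c[nH]c4ccccc34)=C2C#N)cc1` gives 18.5%. The steps of a number 13.6 percentage points lower from compound 1 to compound 3 (beyond the scatter) and a number 13 percentage points lower from compound 2 to compound 3 (beyond the scatter) both exchange the group on the saturated ring carbon, whereas a number 0.6 percentage points lower from compound 1 to compound 2 (within the scatter). Compound 4 `N#CC1=C(N)OC(c2c[nH]c3ccccc23)=C(C#N)C1c1ccccc1Cl` carries 2-chlorophenyl in place of 4-methylphenyl on a saturated ring carbon. Within the data shown here, no measured step introduces 2-chlorophenyl, so only the size of the two aryl exchanges guides the expectation: a modest move of comparable size, more likely upward from the lowest number, or none beyond the scatter. Compound 4 is expected to give 11%, with a range from 1% to 26%. The expected step is a number 5.5 percentage points higher from compound 3 to compound 4 (within the scatter).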

Compound 4, a percentage reported as activity, at one concentration (the size of the read-out at that concentration, not a potency): 10.4%
The estimate for compound 4 lay 0.6 percentage points above the measured number; the range from low to high includes it.
By their numbers in this assay, from the lowest: compounds 3, 4, 2 and 1 (each within the scatter of the next, the first and the last beyond it).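

In this assay, among these compounds, 2-chlorophenyl on the saturated ring carbon is the first group here with no step beyond the scatter to any other, as a number 4.9 percentage points higher from compound 3 to compound 4 (within the scatter) and a number 8.1 percentage points lower from compound 2 to compound 4 (within the scatter) and a number 8.7 percentage points lower from compound 1 to compound 4 (within the scatter) all show. Compound 4 thus falls on neither side of the gap separating compound 3 from compounds 1 and 2, so the series no longer splits into two clear levels at this position. No measurement available here explains these numbers. Still open, from the compounds shown here alone, is how 4-chlorophenyl or a cyclohexyl group would read at this carbon, and all four compounds keep the 1H-indol-3-yl group, so its contribution remains untested here.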